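The source may report more compounds than this note shows. Statements on the series, on what has been measured and on what is new or still open speak of the compounds shown alone.

Of the compounds shown here, three with a shared core have been measured: compound 1 `COc1cccc(N2CCN(C(=O)C(C)N3C(=O)CCC3=O)CC2)c1`, compound 2 `CC(C(=O)N1CCN(c2ccccc2F)CC1)N1C(=O)CCC1=O` and compound 3 `CCC(C(=O)N1CCN(c2cccc(Cl)c2)CC1)N1C(=O)CCC1=O`. In a functional assay on the whole organism (strain Swiss) with Mus musculus as the target, in the maximal electroshock model, with a stated time of 1 h, at a dose of 100 mg/kg by the intraperitoneal route (a higher number here means a stronger effect of the compound at the dose given, a lower number a weaker effect), compound 1 gives 0%, compound 2 gives 0% and compound 3 gives 0%. Within the data shown here, the only step between two measured compounds that differ in a single place, no change at the digits printed from compound 1 to compound 2 (within the scatter), leaves the read-out where it was. Compound 3 therefore stands level with compound 1 and compound 2 in this assay, and none of the three shows an effect at the dose given.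

Compound 4 `CC(C(=O)N1CCN(c2cccc(Cl)c2)CC1)N1C(=O)CCC1=O` has not yet been measured. It differs from compound 3 in one place: hydrogen in place of methyl on a saturated chain carbon, two bonds along the chain from an amide-type nitrogen in a ring and a carbonyl carbon. Among the measured compounds shown here, no measured step touches this chain carbon, so the only guide is that compound 1, compound 2 and compound 3 all sit at the same read-out in this assay with no effect. Compound 4 is accordingly expected to give 0%, within 0% to 10%, in this assay. The expected step is no change at the digits printed from compound 3 to compound 4 (within the scatter), that is, nothing beyond the scatter.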

Compound 4, a percentage reported as activity, at one dose (the size of the read-out at that dose, not a potency): 50%
Compound 4: middle estimate off by 50 percentage points, on the low side; the whole stated range lies below it.
By their numbers in this assay, from the lowest: compounds 1, 2 and 3 (each within the scatter of the next); then compound 4.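

In this assay, the saturated chain carbon proves sensitive to a single heavy atom: hydrogen in place of methyl there, which reads as ethyl to methyl when cut one bond further out, gives a number 50 percentage points higher from compound 3 to compound 4 (beyond the scatter) and separates two compounds that share the 3-chlorophenyl group. Among these compounds, with the methyl chain held, the aryl group also counts, something the earlier compounds could not reveal: 3-chlorophenyl in place of 2-fluorophenyl gives a number 50 percentage points higher from compound 2 to compound 4 (beyond the scatter) and chloro in place of methoxy on an aromatic carbon gives a number 50 percentage points higher from compound 1 to compound 4 (beyond the scatter) as well. Nothing available explains these steps.

On these data alone, it remains open whether ethyl to methyl has the same effect with 2-fluorophenyl or 3-methoxyphenyl on the amine nitrogen. Also open, as far as these compounds go, is how a hydroxyl or an amine on this chain carbon, or a trifluoromethyl group in place of chloro, would read out.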